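This account rests on a few compounds, and the source may have more. Where it says the series, first, only, none or still open, it means among the compounds named here.

Measured so far in a functional assay (aorta) with Rattus norvegicus as the target; a lower number here means that less compound is needed, a higher number that more compound is needed for the effect:
- compound 1 `COc1ccc(-c2nc(CNC(C)=O)sc2-c2ccc(OC)cc2)cc1`: 8.1 uM
- compound 2 `COc1ccc(-c2nc(C(=O)N3CCCCC3CCO)sc2-c2ccc(OC)cc2)cc1`: 6.8 uM
- compound 3 `COc1ccc(-c2nc(C(=O)N3CCNC(CCO)C3)sc2-c2ccc(OC)cc2)cc1`: 9.5 uM

Compound 1 stands second highest of the three numbers; its nearest neighbour is compound 3 and its furthest compound 2, both gaps within the scatter, so the three are treated as one cluster. For the measured compounds named here, the only single-point step measured, a 1.4-fold higher number from compound 2 to compound 3 (0.15 log units; within the scatter), concerns the group on a carbonyl carbon and is within the scatter.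

Compound 4 `CCOC(=O)/C=C/c1nc(-c2ccc(OC)cc2)c(-c2ccc(OC)cc2)s1` differs from compound 1 by 2-(ethoxycarbonyl)ethenyl in place of acetamidomethyl on an aromatic carbon. Going by the values given here, no measured step bears directly on this change; the one available step lies at another part of the molecule and is small. The expected step is therefore a 1.2-fold higher number from compound 1 to compound 4 (0.09 log units; within the scatter), nothing beyond the scatter, with wide uncertainty. Compound 4 is estimated at 10 uM, range 4 uM to 30 uM.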

Compound 4, concentration for half-maximal effect: > 100 uM
Compound 4 gave a limit, no number; the forecaster's own chance of this, stated with the estimate: 10%; middle value at least 10-fold (1.00 log units) away from the limit.
By their numbers in this assay, from the lowest: compounds 2, 1 and 3 (each within the scatter of the next). At a limit, above all of these: compound 4.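

In this assay, the aromatic carbon next to the ring nitrogen and next to the ring sulfur proves sensitive to its substituent, with 2-(ethoxycarbonyl)ethenyl in place of acetamidomethyl giving an at least 12-fold higher number from compound 1 to compound 4 (1.09 log units; beyond the scatter). Compound 1, compound 2 and compound 3, with their different groups here, had stayed within the scatter of one another and gave no sign of this. Compound 4 reads only as a limit: the limit of > 100 uM in this assay, at which 1 of the 4 values shown sits.

Which part of 2-(ethoxycarbonyl)ethenyl accounts for the step stays open, as does how far compound 4 lies past its limit. As far as these compounds go, how a carboxylic acid or a saturated ester chain would read at this position is also open.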